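The source may hold more compounds than are shown below. What is called first, only, known or untested is meant among the compounds shown, and "the series" means these compounds.

Of the compounds shown here, two sharing one core have so far been read in a physicochemical assay for lipophilicity, read by HPLC, at pH 7.4; on this read-out higher numbers stand for higher lipophilicity and lower numbers for lower lipophilicity. Compound 1 `C[C@@H](Oc1cc2oc(=O)n(CCC(=O)O)c2cc1Cl)c1ccc(F)cn1` gives 1.98 and compound 2 `C[C@@H](Oc1cc2oc(=O)n(CCC(=O)O)c2cc1Cl)c1ncco1` gives 1.11, so compound 2 holds the lower of the two numbers. Compound 3 `Cc1cccc([C@@H](C)Oc2cc3oc(=O)n(CCC(=O)O)c3cc2Cl)n1` has not yet been measured. Its difference from compound 2 is this: 6-methylpyridin-2-yl in place of 1,3-oxazol-2-yl on a saturated chain carbon bound to an oxygen on an aromatic ring and a saturated chain carbon. In words, 6-methylpyridin-2-yl stands in place of 1,3-oxazol-2-yl on a saturated chain carbon bound to an oxygen on an aromatic ring and a saturated chain carbon. Within the data shown here, only one measured step bears on this change: a number 0.87 log units lower from compound 1 to compound 2 (beyond the scatter). That step put the same 1,3-oxazol-2-yl in place of 5-fluoropyridin-2-yl. The new change leaves 1,3-oxazol-2-yl for a different pyridinyl group, so a step of similar size, in the opposite direction, is expected in this assay. The expected change is a number 0.89 log units higher from compound 2 to compound 3 (beyond the scatter). In this assay the estimate for compound 3 is 2, with an expected range of 1.6 to 2.4.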

Compound 3, distribution coefficient: 2.12
The estimate for compound 3 lay 0.12 log units below the measured number; measured number inside the range.
By their numbers in this assay, from the lowest: compound 2; then compounds 1 and 3 (each within the scatter of the next).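

At this position, on a saturated chain carbon bound to an oxygen on an aromatic ring and a saturated chain carbon, a second pyridinyl group now stands against 1,3-oxazol-2-yl in this assay, with a number 1.01 log units higher from compound 2 to compound 3 (beyond the scatter). The earlier step, a number 0.87 log units lower from compound 1 to compound 2 (beyond the scatter), therefore no longer rests on 5-fluoropyridin-2-yl alone, and among these three compounds only compound 2, with its 1,3-oxazol-2-yl, stands apart. The two pyridinyl groups cannot be told apart here, with a number 0.14 log units higher from compound 1 to compound 3 (within the scatter), so swapping 5-fluoropyridin-2-yl for 6-methylpyridin-2-yl leaves the read-out within the usual scatter.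

An unsubstituted phenyl or a 1,3-thiazol-2-yl at this place would help show whether the gap follows ring size or hetero atoms, which change together in these compounds. Nothing measured here explains the gap.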